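Amide replacement on the pyrazole-amide series: aryl to cyclopentylmethyl

This account rests on a few compounds, and the source may have more. Where it says the series, first, only, none or still open, it means among the compounds named here.

Measured so far:
compound 1, `O=C(Nc1cc(-c2ccccc2)nn1-c1ccccc1)c1ccccc1`, 203 nM
compound 2, `COc1cc(OC)cc(C(=O)Nc2cc(-c3ccccc3)nn2-c2ccccc2)c1`, 2040 nM

In a functional assay on cells for positive allosteric modulation of metabotropic glutamate receptor 5 (Rattus norvegicus), read by calcium flux (on this read-out lower numbers stand for an effect already at smaller amounts and higher numbers for an effect only at larger amounts of compound), compound 2 stands at the highest number of the two measured, with compound 1 as nearest neighbour at a lower number. Among the measured compounds shown here, the one measured step, a 10-fold higher number from compound 1 to compound 2 (1.00 log units; beyond the scatter), shows that enlarging the group on the carbonyl carbon from phenyl to 3,5-dimethoxyphenyl costs potency beyond the scatter.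

Compound 3, `O=C(CC1CCCC1)Nc1cc(-c2ccccc2)nn1-c1ccccc1`, is not yet measured. Its change from compound 2 is cyclopentylmethyl in place of 3,5-dimethoxyphenyl on a carbonyl carbon. This step leaves the aryl amide series altogether, so the measured step bears on it only indirectly: it shows the assay responds to what sits on the carbonyl carbon, but not how a non-aromatic group fares there. Either direction remains open; an expectation of a number near compound 2, with a wide range, is therefore the working estimate, giving a 1.5-fold higher number from compound 2 to compound 3 (0.17 log units; within the scatter). For compound 3 the estimate is 3000 nM, with a range from 600 nM to 15000 nM.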

Compound 3, half-maximal effective concentration: 350 nM
Beside the measured number, compound 3's estimate is 8.6-fold (0.93 log units) above it; measured number outside the range, below it.
By their numbers in this assay, from the lowest: compounds 1 and 3 (each within the scatter of the next); then compound 2.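

In this assay, the position on the carbonyl carbon proves not to be limited to aromatic groups: cyclopentylmethyl in place of 3,5-dimethoxyphenyl gives a 5.8-fold lower number from compound 2 to compound 3 (0.77 log units; beyond the scatter). Set against the unsubstituted phenyl, cyclopentylmethyl gives a 1.7-fold higher number from compound 1 to compound 3 (0.24 log units; within the scatter), so in this series a non-aromatic ring on the carbonyl carbon and a phenyl cannot be told apart by this read-out, and compound 2 alone stands apart from the other two. No measurement at hand bears on the reason for this result.

The change from compound 2 to compound 3 alters the ring type, the heavy-atom count and the presence of the two oxygens all at once, so the compounds shown do not tell which of these differences goes with the shift in number. Also open, from the compounds shown here alone, is how the series responds to a phenyl carrying a single methoxy group, to a cyclopentyl group with no intervening methylene on the carbonyl carbon, or to a longer chain such as cyclopentylethyl.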